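From 2-bromophenyl to 3-bromophenyl on the amine nitrogen

The compounds below may be only part of what the source reports. "The series", "measured", "known", "first", "only" and "open" are said of these compounds alone.

Of the compounds shown here, two sharing one core have been measured in a functional assay, with a stated time of 6 min; on this read-out lower numbers stand for stronger inhibition and higher numbers for weaker inhibition. Compound 1 (`Fc1cccc(F)c1NCn1nc(-c2ccc3c(c2)OCCO3)oc1=S`) gives 3320 nM, while compound 2 (`S=c1oc(-c2ccc3c(c2)OCCO3)nn1CNc1ccccc1Br`) gives 12700 nM, the higher of the two numbers. Compound 3 (`S=c1oc(-c2ccc3c(c2)OCCO3)nn1CNc1cccc(Br)c1`) differs from compound 2 in one place: 3-bromophenyl in place of 2-bromophenyl on an amine nitrogen. In words, it carries 3-bromophenyl in place of 2-bromophenyl on an amine nitrogen.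

For the measured compounds named here, only one measured step bears on this change: a 3.8-fold higher number from compound 1 to compound 2 (0.58 log units; beyond the scatter). There, 2-bromophenyl replaced 2,6-difluorophenyl on the same amine nitrogen. That modest step, beyond the scatter, shows that a change in this group can move the read-out. Going by the values given here, no measured pair, however, compares 2-bromophenyl with 3-bromophenyl, so its size serves only as a rough guide. Since compound 2 stands at the high end with 12700 nM, a small move towards a lower number is expected, though it may not clear the scatter. The expected change is a 1.8-fold lower number from compound 2 to compound 3 (0.26 log units; within the scatter). For compound 3 the estimated value in this assay is 7000 nM, with an expected range of 2500 nM to 20000 nM.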

Compound 3, half-maximal inhibitory concentration: 10800 nM
For compound 3 the middle estimate is 1.5-fold (0.19 log units) below the measured one; low and high end bracket the measured number.
By their numbers in this assay, from the lowest: compound 1; then compounds 3 and 2 (each within the scatter of the next).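

In this assay, 3-bromophenyl in place of 2-bromophenyl on the amine nitrogen gives a 1.2-fold lower number from compound 2 to compound 3 (0.07 log units; within the scatter), so this read-out does not separate the two bromophenyl compounds, and for this pair the change of bromine position has no effect beyond the scatter. Compared with the 2,6-difluorophenyl group, compound 3 gives a 3.3-fold higher number from compound 1 to compound 3 (0.51 log units; beyond the scatter), so both bromophenyl compounds now stand apart from compound 1, which has the lowest number of the three and thus the strongest inhibition. No measured evidence is available to account for either the step between the two bromophenyl compounds or their gap to compound 1.

The compounds shown leave open whether that gap follows from the presence of fluorine, from the presence of bromine or from the number of groups on the ring, a question that a plain phenyl group or a chlorophenyl group on the same nitrogen would help to settle. They also leave open how far the shared core contributes, as all three compounds differ only in this one group.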